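A Second Hydroxy Group on Compound 3

The source may report more compounds than this note shows. Statements on the series, on what has been measured and on what is new or still open speak of the compounds shown alone.

In a functional assay on SW-620 cells (Homo sapiens) for cytotoxicity, read by MTT assay, with a stated time of 72 h (a lower number here means a stronger inhibitor, a higher number a weaker inhibitor), compound 1 `COc1cccc(/C=C2\CCC/C(=C\c3ccc(O)cc3)C2=O)c1OC` returns only a limit of > 20000 nM. Compound 2 `COc1ccc(/C=C2\CCC/C(=C\c3ccccc3Br)C2=O)cc1OC` gives 5300 nM, while compound 3 `COc1ccc(/C=C2\CCC/C(=C\c3cccc(O)c3)C2=O)cc1OC` gives 1900 nM, the lower of the two actual numbers. Compound 4 `COc1ccc(/C=C2\CCC/C(=C\c3ccc(O)c(O)c3)C2=O)cc1OC` carries hydroxy in place of hydrogen on an aromatic carbon, ortho to a hydroxy group and para to a large group, turning 3-hydroxyphenyl into 3,4-dihydroxyphenyl: hydroxy in place of hydrogen on an aromatic carbon. For the measured compounds named here, the only measured step that bears on this change is the modest 2.8-fold lower number from compound 2 to compound 3 (0.45 log units; beyond the scatter), which installed the 3-hydroxyphenyl group. A step no larger than that, leaning toward a lower number, is therefore expected in this assay, estimated as a 1.7-fold lower number from compound 3 to compound 4 (0.24 log units; within the scatter). Compound 4 is expected at 1100 nM, with an estimated range of 350 nM to 3800 nM.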

Compound 4, half-maximal inhibitory concentration: 10500 nM
Estimate against measurement, compound 4: 9.5-fold (0.98 log units) below; measured number above the stated range.
By their numbers in this assay, from the lowest: compound 3; then compounds 2 and 4 (each within the scatter of the next). At a limit, above all of these: compound 1.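

In this assay, this position did not extend the gain from the 3-hydroxyphenyl group: hydroxy on the aromatic carbon ortho to that hydroxy group gives a 5.5-fold higher number from compound 3 to compound 4 (0.74 log units; beyond the scatter). That single added hydroxy cancels the earlier gain, since the listed comparison shows a 2.0-fold higher number from compound 2 to compound 4 (0.30 log units; within the scatter), which leaves 3,4-dihydroxyphenyl level with 2-bromophenyl. Nothing shown here accounts for this reversal. The compounds shown leave open whether the rise is specific to hydroxy, or whether an amino group or a fluorine on the same carbon would raise the number too.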